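The source may report more compounds than this note shows. Statements on the series, on what has been measured and on what is new or still open speak of the compounds shown alone.

Measured so far in a functional assay on HUVEC cells (Homo sapiens) for inhibition, with a stated time of 4 days; a lower number here means a stronger inhibitor, a higher number a weaker inhibitor:
- Compound 1 `CCc1ccc(OC)c(COc2ccc(Cl)c(C)c2)c1`: 40000 nM
- Compound 2 `COc1ccc(C(=O)O)cc1COc1ccc(Cl)c(C)c1`: > 50000 nM (a limit of the assay)

Compound 2 has no number, only the limit > 50000 nM. Its standing is therefore open on the weak side, and no true value can be read from it.

The next compound is compound 3 `COc1ccc(C(N)=O)cc1COc1ccc(Cl)c(C)c1`. The change is amino in place of hydroxy on a carbonyl carbon, which amounts to carboxy to carbamoyl.

Among the measured compounds shown here, only one measured step bears on this, and it is an at least 1.2-fold higher number from compound 1 to compound 2 (0.09 log units; that floor lies within the scatter). That step replaced ethyl with carboxy on an aromatic carbon, so it concerns the same group of compound 2 but not the same exchange. For the measured compounds named here, its size is only a floor, and the data contain no measured step for the exchange of hydroxy for amino. Going by the values given here, the one firm number in this assay remains compound 1 at 40000 nM, so the expectation rests on that value and no step beyond the scatter is expected. The expected step is an at least 1.2-fold lower number from compound 2 to compound 3 (0.09 log units; that floor lies within the scatter), and a reading at the limit would not be surprising.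

For compound 3 the estimated value is 40000 nM, with an expected range of 15000 nM to 50000 nM.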

Compound 3, half-maximal inhibitory concentration: 640 nM
Compound 3: middle estimate off by 63-fold (1.80 log units), on the high side, and the stated range ends above it.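

In this assay, among the compounds shown here, the aromatic carbon that bears ethyl in compound 1 proves sensitive to its substituent: carbamoyl there gives a 63-fold lower number from compound 1 to compound 3 (1.80 log units; beyond the scatter), the only step with a firm size beyond the scatter. Amino in place of hydroxy on a carbonyl carbon gives an at least 78-fold lower number from compound 2 to compound 3 (1.89 log units; beyond the scatter), so a swap of one heavy atom, with the same counts of hydrogen-bond donors and acceptors for the two groups, separates the two compounds by far more than the scatter. That step is only a floor, and its true size stays unknown because compound 2 has only a limit of the assay: the limit of > 50000 nM in this assay, at which 1 of the 3 values shown sits.

Still open, as far as these compounds go, is whether the amide hydrogens matter or the carbamoyl group as a whole, a question that a methyl amide and a dimethyl amide at this place would help to separate. Also open, from the compounds shown here alone, is how a nitrile, a methyl ester or a sulfonamide on the same aromatic carbon would read, and whether the step holds on other variants of the shared core.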